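Methyl Additions on a Shared Anilinopyrimidine Core

This account rests on a few compounds, and the source may have more. Where it says the series, first, only, none or still open, it means among the compounds named here.

Compound 1 `Cc1cccc(Nc2nccc(-c3cc(C)oc3C)n2)c1` gives 28500 nM in a functional assay for inhibition, with Homo sapiens as the target; a lower number here means a stronger inhibitor, a higher number a weaker inhibitor.
Compound 2 `Cc1cc(C)cc(Nc2nccc(-c3cc(C)oc3C)n2)c1` gives 4100 nM in this assay.
Compound 3 `CCN(CC)c1ccc(Nc2nccc(-c3ccco3)n2)cc1` gives 8700 nM in this assay.

Compound 1 and compound 2 share a core and differ in one place: methyl in place of hydrogen on an aromatic carbon. That change made a step of a 7.0-fold lower number from compound 1 to compound 2 (0.84 log units; beyond the scatter), a modest gain that lies beyond the scatter. Compound 3 stands second highest of the three numbers; its nearest neighbour is compound 2, its furthest is compound 1. The difference between the core of compound 3 and the core of compound 1 is not broken down here.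

Compound 4 `CCN(CC)c1ccc(Nc2nccc(-c3ccc(C)o3)n2)cc1` has not yet been measured. It differs from compound 3 by methyl in place of hydrogen on an aromatic carbon. This is the same kind of change as that from compound 1 to compound 2, but not the same: in compound 2 the methyl sits on an aromatic carbon of a six-membered aromatic ring of carbon only, meta to a large group and meta to a methyl group, whereas in compound 4 it sits on an aromatic carbon of a five-membered aromatic ring with one oxygen, next to the ring oxygen, two ring bonds from the ring atom that bears a large group.

Within the data shown here, for compound 4 a step of a 2.2-fold lower number from compound 3 to compound 4 (0.34 log units; beyond the scatter) is expected in this assay, smaller than the step from compound 1 to compound 2, since that earlier step of a 7.0-fold lower number from compound 1 to compound 2 (0.84 log units; beyond the scatter) was made at a different place and is the only guide. Compound 4 is thus estimated at 4000 nM, with a likely range from 1500 nM to 12000 nM.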

Compound 4, half-maximal inhibitory concentration: 28000 nM
Estimate against measurement, compound 4: 7.0-fold (0.85 log units) below; measured number above the stated range.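

The change from furan-2-yl to 5-methylfuran-2-yl gives a 3.2-fold higher number from compound 3 to compound 4 (0.51 log units; beyond the scatter) in this assay, so the number rises here where the earlier methyl addition on the core of compound 1 lowered it. Set side by side, the two steps run in opposite directions and do not agree, so in this series the effect of adding a methyl to an aromatic carbon did not carry from one core to the other: the same change on two cores in this assay, a 7.0-fold lower number (0.84 log units; beyond the scatter) from compound 1 to compound 2 and a 3.2-fold higher number (0.51 log units; beyond the scatter) from compound 3 to compound 4, 22-fold (1.35 log units) apart, beyond the scatter of two such steps. This does not show what sets the direction, since the two methyl groups sit on different rings, one on a six-membered aromatic ring of carbon only and the other on a five-membered aromatic ring with one oxygen, and the rest of the two cores differs as well, so place and core cannot be told apart from just these two pairs.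

The compounds shown leave open how a methyl on that five-membered ring, next to the ring oxygen, would read on the core of compound 1, and how a methyl on the ring of carbon only would read on the core of compound 3. Also open, from the compounds shown here alone, is whether a longer chain such as ethyl, or a methoxy group, at the place of the methyl in compound 4 would give a number nearer that of compound 3 or that of compound 4.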